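Two Measured Compounds and an Azido Step

The source may report more compounds than this note shows. Statements on the series, on what has been measured and on what is new or still open speak of the compounds shown alone.

Measured so far in a functional assay on MGC-803 cells (Homo sapiens) for inhibition, read by CCK-8 assay, with a stated time of 48 h (a higher number here means a weaker inhibitor, a lower number a stronger inhibitor), are two compounds
compound 1 `COc1ccc(CN(C(=O)CN2CCN(C(=O)OC(C)(C)C)CC2)c2cc(OC)c(OC)c(OC)c2)cc1` gives 9500 nM
compound 2 `COc1cc(N(Cc2ccc(C)cc2)C(=O)CSC(=S)N2CCN(C(=O)OC(C)(C)C)CC2)cc(OC)c1OC` gives 16700 nM

The gap between compound 2 at 16700 nM and compound 1 at 9500 nM lies within the usual scatter, so neither stands apart from the other.

The next compound, compound 3 `COc1ccc(CN(C(=O)CSC(=S)N2CCN(C(=O)OC(C)(C)C)CC2)c2cc(OC)c(OC)c(OC)c2)cc1N=[N+]=[N-]`, keeps the rest of compound 2 and carries 3-azido-4-methoxyphenyl in place of 4-methylphenyl on a saturated chain carbon bound to an amide-type nitrogen. The same difference reads as 4-methylbenzyl to 3-azido-4-methoxybenzyl.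

Among the compounds with values here, no two measured compounds differ in one place only, so this change has no direct precedent in this assay here. A moderate step toward a lower number, meaning a stronger inhibitor, is expected, and it may not clear the scatter by much. With so little to go on, the range has to stay wide.

The estimated size of the change is (a 3.3-fold lower number from compound 2 to compound 3 (0.52 log units; beyond the scatter)) in this expectation. For compound 3 the expected value is 5000 nM with an estimated range from 800 nM to 20000 nM as the likely span.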

Compound 3, half-maximal inhibitory concentration: 810 nM
Compound 3: the middle estimate sits 6.2-fold (0.79 log units) above what was measured, within the range that was stated.
By their numbers in this assay, from the lowest: compound 3; then compounds 1 and 2 (each within the scatter of the next).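

In this assay, within the data shown here, the group on a saturated chain carbon bound to an amide-type nitrogen turns out to matter a great deal: replacing 4-methylbenzyl with 3-azido-4-methoxybenzyl gives a 21-fold lower number from compound 2 to compound 3 (1.31 log units; beyond the scatter), whereas the earlier compounds offered no comparison of a change in one place. This is therefore the first sign that the read-out responds to a single substitution at this place, with the rest of the molecule held constant and the entering group carrying 11 heavy atoms against 7 and 2 hydrogen-bond acceptors against 0. Nothing measured on these compounds speaks to why the number fell so far.

The azido and methoxy groups arrive together and the methyl group leaves in the same step, so the compounds shown cannot divide the drop among them. From the compounds shown here alone, it remains open whether 4-methoxybenzyl alone, or 3-amino-4-methoxybenzyl with an amine in place of the azido, would keep the lower number, and whether the same exchange would do as much on a different core.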